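The source may report more compounds than this note shows. Statements on the series, on what has been measured and on what is new or still open speak of the compounds shown alone.

Measured compounds:
compound 1 `CC(C)NC(=O)Nc1nc2ccc(Br)cc2s1` gives 22800 nM in a functional assay (thoracic aorta, Rattus norvegicus, strain Wistar); a lower number here means that less compound is needed, a higher number that more compound is needed for the effect.
Compound 2 `O=C(Nc1nc2ccc(Br)cc2s1)Nc1ccc(C(F)(F)F)cc1Cl` gives > 100000 nM in this assay, a limit of the measurement rather than a number.

Compound 2 thus stands at the limit of > 100000 nM in this assay, at which 1 of the 2 values shown sits. Compound 3 `O=C(Nc1nc2ccc([N+](=O)[O-])cc2s1)Nc1ccc(C(F)(F)F)cc1Cl` differs from compound 2 by nitro in place of bromo on an aromatic carbon. Among the measured compounds shown here, no step between measured compounds is available to set the size of this change. The step expected, a step that the limit leaves unreadable from compound 2 to compound 3, is none beyond the scatter in this assay. Compound 3 is estimated at 120000 nM, with a range from 30000 nM to 400000 nM, and a limit is the likelier report.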

Compound 3, half-maximal effective concentration: 54300 nM
Beside the measured number, compound 3's estimate is 2.2-fold (0.34 log units) above it, within the range that was stated.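

In this assay, among the compounds shown here, nitro in place of bromo on this aromatic carbon gives the first actual number for a compound carrying the chloro and trifluoromethyl substituted phenyl group, with a step of an at least 1.8-fold lower number from compound 2 to compound 3 (0.26 log units; that floor lies within the scatter). The change therefore moves the read-out from a limit to a number, although the floor of the step does not exceed the usual scatter. The full size of the step remains unknown because compound 2 is held at a limit: the limit of > 100000 nM in this assay, at which 1 of the 3 values shown sits.

From the compounds shown here alone, whether an amine or a nitrile at this position would also give a number remains open. So does the effect of the same change on the shared core with the side chain of compound 1.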